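Fluoro in place of 4-methoxyphenyl on the shared core

The source may hold more compounds than are shown below. What is called first, only, known or untested is meant among the compounds shown, and "the series" means these compounds.

Compound 2 `COc1ccc(-c2ccc3c(c2)oc(=O)n3C(=O)NCCCCc2ccccc2)cc1` gives 67 nM in an assay on HEK293 cells for inhibition of acid ceramidase (Homo sapiens), with a stated time of 10 min (a lower number here means a stronger inhibitor, a higher number a weaker inhibitor), and stands with the highest number of the three measured compounds. Compound 1 `O=C(NCCCCc1ccccc1)n1c(=O)oc2ccc(Cl)cc21` gives 15 nM in this assay, and compound 3 `O=C(NCCCCc1ccccc1)n1c(=O)oc2ccc(Br)cc21` gives 22 nM; both lie below compound 2 by more than the scatter, compound 3 being the nearer of the two.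

Compound 4 `O=C(NCCCCc1ccccc1)n1c(=O)oc2cc(F)ccc21` differs from compound 2 by fluoro in place of 4-methoxyphenyl on an aromatic carbon, placed on the carbon described for it. Among the measured compounds shown here, the only measured step on this core is a 1.5-fold higher number from compound 1 to compound 3 (0.17 log units; within the scatter), an exchange of one halogen for another that stays within the scatter. For the measured compounds named here, no measured pair covers the exchange of 4-methoxyphenyl for a halogen, nor a halogen at this place on the ring. Since both halogen compounds, compound 1 with 15 nM and compound 3 with 22 nM, sit beyond the scatter below compound 2, a lower number is expected for compound 4 in this assay. Compound 4 is estimated at 25 nM, within a range of 10 nM to 65 nM. The expected step is a 2.7-fold lower number from compound 2 to compound 4 (0.43 log units; beyond the scatter).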

Compound 4, half-maximal inhibitory concentration: 31 nM
Compound 4: the middle estimate sits 1.2-fold (0.09 log units) below what was measured; the range from low to high includes it.
By their numbers in this assay, from the lowest: compounds 1, 3 and 4 (each within the scatter of the next, the first and the last beyond it); then compound 2.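

In this assay, among the compounds shown here, fluoro in place of 4-methoxyphenyl gives a 2.2-fold lower number from compound 2 to compound 4 (0.33 log units; beyond the scatter), a modest step but the first measured exchange at this place on the shared core. It shows that the whole 4-methoxyphenyl, with its six-membered aromatic ring, can give way to a single fluoro without any rise in the number, so that group is not needed here for inhibition at this level. Nothing at hand gives a reason for the step.

Whether the step reflects the arrival of fluoro or only the departure of 4-methoxyphenyl stays open: the compounds shown hold just these two groups at this place. Plain hydrogen, an amine, a carboxylic acid or an unsubstituted phenyl here would help separate the two readings.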